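Cyano in place of hydrogen on the phenoxy ring

This account rests on a few compounds, and the source may have more. Where it says the series, first, only, none or still open, it means among the compounds named here.

Measured compounds and their values:
compound 1 `Cc1cc(COc2ccccc2)nc(-c2ccccn2)n1` — 794 nM
compound 2 `COc1cccc(OCc2cc(C)nc(-c3ccccn3)n2)c1` — 2000 nM
compound 3 `COc1ccc(OCc2cc(C)nc(-c3ccccn3)n2)cc1` — 7940 nM

In a functional assay on cells for antagonist activity at Free fatty acid receptor 1 (Homo sapiens), read by TR-FRET and inositol phosphate accumulation, with a stated time of 2 h (a higher number here means a weaker inhibitor, a lower number a stronger inhibitor), compound 1 gives the lowest of the three numbers; compound 2 comes nearest, and compound 3 lies furthest away. Both measured changes add a methoxy to the phenoxy ring of the shared core, and both raise the number: a 2.5-fold higher number from compound 1 to compound 2 (0.40 log units; beyond the scatter) and a 10-fold higher number from compound 1 to compound 3 (1.00 log units; beyond the scatter). The unmeasured compound 4 `Cc1cc(COc2ccccc2C#N)nc(-c2ccccn2)n1` differs from compound 1 in a different way: cyano in place of hydrogen on an aromatic carbon. Among the compounds with values here, the two measured steps bear on this change only loosely, since they place a methoxy rather than a cyano on the ring and at other carbons; no measured step puts any group ortho to the large group. What the two steps show is that adding a group to this ring of compound 1 has so far weakened inhibition in this assay, by a modest to sizeable amount. For compound 4 a modest weakening beyond the scatter is therefore expected, smaller than the step to compound 3, and the step is estimated as a 1.8-fold higher number from compound 1 to compound 4 (0.25 log units; within the scatter). Compound 4 is thus expected to give about 1400 nM in this assay, within a range of 500 nM to 4000 nM.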

Compound 4, half-maximal inhibitory concentration: 10000 nM
The estimate for compound 4 lay 7.1-fold (0.85 log units) below the measured number, and the stated range ends below it.
By their numbers in this assay, from the lowest: compound 1; then compound 2; then compounds 3 and 4 (each within the scatter of the next).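

In this assay, within the data shown here, cyano in place of hydrogen on an aromatic carbon, ortho to a large group, gives a 13-fold higher number from compound 1 to compound 4 (1.10 log units; beyond the scatter) and is the only step of the three rated large, the two methoxy steps having been rated modest. It is also the only step shown that places a group at this position and the only one that introduces a group other than methoxy, so the rise in the number now extends beyond methoxy and beyond the carbons that carried it: all three compounds with an added group on the phenoxy ring, compound 2, compound 3 and compound 4, give higher numbers than compound 1, and none goes against this. No measurement is available here that accounts for the size of this step.

The compounds shown do not separate the effect of the cyano from that of its position, so the result could belong to the group, the carbon it occupies, or both. A methoxy, a fluorine or a methyl at this same carbon would bear on that question, and a carboxylic acid or an amine there would show whether any group on this carbon can lower the number.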